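The compounds below may be only part of what the source reports. "The series", "measured", "known", "first", "only" and "open" are said of these compounds alone.

Measured so far:
compound 1, `CNC(=O)N1CCCc2ccc(NC(=O)c3cccc(-c4ccn(C(C)=O)n4)c3)cc21`: 27.6%
compound 2, `CNC(=O)N1CCCc2ccc(NC(=O)c3ccc(-c4cnn(S(C)(=O)=O)c4)cc3)cc21`: 4.5%

In a functional assay on MV4-11 cells (Homo sapiens) for antiproliferative activity, with a stated time of 6 days, tested at 1.56 uM (a lower number here means a weaker effect, a higher number a stronger effect of the compound at the concentration tested), compound 1 gives the higher of the two numbers; compound 2 lies lower, beyond the scatter. Compound 3 `CNC(=O)N1CCCc2ccc(NC(=O)c3cccc(-c4ccn(S(C)(=O)=O)n4)c3)cc21` is compound 1 with methylsulfonyl in place of acetyl on an aromatic nitrogen. Among the compounds with values here, no single-change step between measured compounds is at hand; compound 2 carries the same entering group yet differs from compound 1 in more than one place, so its value is only a rough hint. The step of a number 9.6 percentage points lower from compound 1 to compound 3 (within the scatter) is expected to be a modest loss, in the direction of weaker effect, possibly no larger than the scatter. For compound 3 the estimate is 18%, with a range of 4% to 34%.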

Compound 3, a percentage reported as inhibition, at one concentration (the size of the read-out at that concentration, not a potency): 4.03%
The estimate for compound 3 lay 14 percentage points above the measured number; the measured number falls inside the stated range.
By their numbers in this assay, from the lowest: compounds 3 and 2 (each within the scatter of the next); then compound 1.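

In this assay, replacing acetyl with methylsulfonyl on the aromatic nitrogen gives a number 23.6 percentage points lower from compound 1 to compound 3 (beyond the scatter). Within the data shown here, this is the first single-change reading at this position: with the rest of compound 1 held fixed, the swap of this one group alone moves the read-out by more than the scatter. No measurement at hand gives a cause for this step.

Open, from the compounds shown here alone, is whether a simple methyl, a longer acyl chain such as propanoyl or a urea on this nitrogen would keep the effect of acetyl. Also open, going by these compounds, is whether acetyl itself is needed, which the unsubstituted ring nitrogen would test.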